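The compounds below may be only part of what the source reports. "The series", "measured", "known", "first", "only" and "open" are said of these compounds alone.

Values in a functional assay on MCF7 cells (Homo sapiens) for cytotoxicity, read by MTT assay, with a stated time of 48 h; on this read-out higher numbers stand for weaker inhibition and lower numbers for stronger inhibition:
- compound 1 `C/C(=N\NC(=S)Nc1ccccc1I)c1ccccn1` gives 4.1 nM
- compound 2 `C/C(=N\NC(=S)Nc1ccccc1Cl)c1ccccn1` gives 0.16 nM
- compound 3 `C/C(=N\NC(=S)Nc1ccccc1)c1ccccn1` gives 0.18 nM

Compound 1 has the highest number of the three and so the weakest inhibition in this assay. The iodo group accounts for the measured separation: chloro in its place gives a 26-fold lower number from compound 1 to compound 2 (1.41 log units; beyond the scatter), and hydrogen in its place gives a 23-fold lower number from compound 1 to compound 3 (1.36 log units; beyond the scatter). Both steps are large. Between the other two compounds, the change from chloro to hydrogen gives a 1.1-fold higher number from compound 2 to compound 3 (0.05 log units; within the scatter), which lies within the scatter.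

Compound 4 `CC(=NNC(=S)Nc1ccccc1I)c1ccccn1` is the next entry, and its relation to compound 1 is the two compounds have the same atoms and bonds; at least one stereo element is drawn with a configuration in one of them and without one in the other: 1 of 1 stereo elements differ; a double bond is drawn E in compound 1 and without a configuration in compound 4. Among the measured compounds shown here, the iodo group stays in place, so none of the measured steps applies directly. For the measured compounds named here, they all concern the aromatic substituent, and no measured pair tests a change in how the double bond is drawn. With identical atoms and bonds, no step beyond the scatter is expected, and compound 1 at 4.1 nM serves as the anchor. The range stays fairly wide, as the sample behind compound 4 may differ in double-bond configuration.

The estimate means a 1.0-fold lower number from compound 1 to compound 4 (0.01 log units; within the scatter), an expected step within the scatter. Compound 4 is expected at 4 nM, with an estimated range of 0.8 nM to 12 nM.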

Compound 4, half-maximal inhibitory concentration: 4.1 nM
Estimate against measurement, compound 4: 1.0-fold (0.01 log units) below; measured number inside the range.
By their numbers in this assay, from the lowest: compounds 2 and 3 (each within the scatter of the next); then compounds 1 and 4 (each within the scatter of the next).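

In this assay, among the compounds shown here, the way the double bond is drawn gives no change at the digits printed from compound 1 to compound 4 (within the scatter), the first reading on this part of the structure, as every earlier step concerned the substituent on the aromatic carbon. The iodo compound thus keeps its number whether the double bond is drawn E or without a configuration, so for this read-out compound 1 and compound 4 can be treated as a single data point for the iodo group. This finding concerns the drawing and does not compare two defined geometries, as the only thing separating the pair is this: the fact that one of compounds 1 and 4 is drawn with a defined configuration and the other without, at the place where they differ

As far as these compounds go, the composition of the sample behind compound 4 remains open, and so does the number a defined Z double bond would give on the same core. From the compounds shown here alone, it is also open whether bromo or methoxy on the aromatic carbon would group with iodo or with chloro and hydrogen, which would show whether the large steps from the iodo group are specific to that one substituent.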